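Isopropylcarbamoyl in place of carbamoyl on a trimethoxybenzyl triazole

The source may report more compounds than this note shows. Statements on the series, on what has been measured and on what is new or still open speak of the compounds shown alone.

Compound 1, `CCNC(=O)N1CCN(C(=S)SCc2cn(Cc3ccccc3F)nn2)CC1`: 23700 nM
Compound 2, `O=C(NC1CCCCC1)N1CCN(C(=S)SCc2cn(Cc3ccc(F)cc3)nn2)CC1`: > 128000 nM
Compound 3, `COc1cc(Cn2cc(CSC(=S)N3CCN(C(N)=O)CC3)nn2)cc(OC)c1OC`: > 128000 nM

In a functional assay on EC9706 cells (Homo sapiens) for cytotoxicity, read by MTT assay, with a stated time of 72 h (on this read-out lower numbers stand for stronger inhibition and higher numbers for weaker inhibition), compound 3 sits at a limit of the assay rather than at a number, one of two such values among the three shown, as the limit of > 128000 nM in this assay, at which 2 of the 3 values shown sit, records. Among the measured compounds shown here, compound 1 alone gives a number, and it is the only compound with an ethyl on the carbamoyl nitrogen. Compound 4, `COc1cc(Cn2cc(CSC(=S)N3CCN(C(=O)NC(C)C)CC3)nn2)cc(OC)c1OC`, is not yet measured; it differs from compound 3 in one place, (isopropyl in place of hydrogen on an amide-type nitrogen). For the measured compounds named here, with no measured step of this kind on hand, only a weak expectation is possible: a step from compound 3 to compound 4 of an at least 1.8-fold lower number from compound 3 to compound 4 (0.26 log units; that floor lies within the scatter), towards stronger inhibition but possibly not beyond the scatter. Compound 4 is therefore estimated at 70000 nM, within 15000 nM to 128000 nM.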

Compound 4, half-maximal inhibitory concentration: > 128000 nM
Compound 4 ended at the assay's limit; the forecaster's own chance of this, stated with the estimate: 55%; middle value at least 1.8-fold (0.26 log units) away from the limit.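

No step can be read from compound 3 to compound 4, as both end at the same limit and not at a number: the limit of > 128000 nM in this assay, at which 3 of the 4 values shown sit.

The compounds shown leave open what isopropyl in place of hydrogen on an amide-type nitrogen does to the inhibition.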